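Solubility notes: carboxy-bearing chain in place of carboxy-bearing amine

The source may hold more compounds than are shown below. What is called first, only, known or untested is meant among the compounds shown, and "the series" means these compounds.

Measured so far in a physicochemical assay for solubility, read by nephelometry, in phosphate buffer, measured as kinetic solubility, at pH 6.5, tested at 10 mg/mL; on this read-out higher numbers stand for higher solubility and lower numbers for lower solubility:
compound 1 `CC(C)(NC(=O)Nc1ccc(F)c(C(F)(F)F)c1)C(=O)O`: > 100 ug/mL
compound 2 `CC(C)(C(=O)O)N1CCCN(c2ccc(F)c(C(F)(F)F)c2)C1=O`: > 100 ug/mL

Compound 1 stands at the top of what this assay can report. The value of compound 1, > 100 ug/mL, is a limit of the assay and not a number. The value of compound 2, > 100 ug/mL, is likewise a limit and not a number. Within the data shown here, both values sit at the limit of > 100 ug/mL in this assay, at which 2 of the 2 values shown sit, so the two compounds cannot be ordered against each other and no measured step exists between them.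

Compound 3 `CC(C)(CC(=O)Nc1ccc(F)c(C(F)(F)F)c1)C(=O)O` is not yet measured. It differs from compound 1 in one place: 2-carboxy-2-methylpropyl in place of (1-carboxy-1-methylethyl)amino on a carbonyl carbon. The shared core is unchanged.

With every measured value at the limit, no step size can be read from the data; compound 3 is expected to remain at the limit rather than move beyond the scatter in either direction. The estimate for compound 3 in this assay is 100 ug/mL, between 50 ug/mL and 150 ug/mL. The expected step of a number no higher from compound 1 to compound 3 (the limit leaves the size open) is thus essentially none beyond the scatter, the most likely outcome being another limit report.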

Compound 3, solubility: 25 ug/mL
Beside the measured number, compound 3's estimate is 4.0-fold (0.60 log units) above it; measured number outside the range, below it.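

In this assay, the position on a carbonyl carbon whose other neighbours are an amide-type nitrogen proves responsive: 2-carboxy-2-methylpropyl in place of (1-carboxy-1-methylethyl)amino gives an at least 4.0-fold lower number from compound 1 to compound 3 (0.60 log units; beyond the scatter). Both groups end in a carboxylic acid, and the listed difference between them is a carbon chain without nitrogen and with 1 hydrogen-bond donor in place of an amino link with 2, so a carboxylic acid on this chain does not by itself keep a compound at the limit. Only the lower bound of the step can be read, because the series sits largely at its top limit: the limit of > 100 ug/mL in this assay, at which 2 of the 3 values shown sit.

Among these compounds, the true size of the step stays open, as does any comparison involving compound 2, since no step to it can be read. Also open, from the compounds shown here alone, is whether an oxygen link or a longer chain at this position, with the carboxylic acid kept, would stay at the limit or fall as compound 3 does, which would show how far the change depends on the amino nitrogen itself.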